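Amino-to-Hydroxy Swap on the Anilino Ring of Compound 3

The source may hold more compounds than are shown below. What is called first, only, known or untested is meant among the compounds shown, and "the series" means these compounds.

Measured compounds:
Compound 1 `Cc1ccc(S(=O)(=O)c2nc3ccccc3nc2Nc2cccc(O)c2)cc1`: 1690 nM
Compound 2 `COc1ccc(Nc2nc3ccccc3nc2S(=O)(=O)c2ccc(Br)cc2)cc1`: 1110 nM
Compound 3 `Nc1cccc(Nc2nc3ccccc3nc2S(=O)(=O)c2ccc(Br)cc2)c1`: 9010 nM

In a functional assay on PC-3 cells (Homo sapiens) for cytotoxicity, read by MTT assay, with a stated time of 72 h (on this read-out lower numbers stand for stronger inhibition and higher numbers for weaker inhibition), compound 3 gives the highest number of the three measured compounds; compound 1 sits nearer to it, compound 2 furthest from it. Among the compounds with values here, the one single-point step measured so far, an 8.1-fold higher number from compound 2 to compound 3 (0.91 log units; beyond the scatter), shows that exchanging the aryl group on the nitrogen of the shared core moves the read-out by a substantial margin.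

Compound 4 `O=S(=O)(c1ccc(Br)cc1)c1nc2ccccc2nc1Nc1cccc(O)c1` is related to compound 3 by hydroxy in place of amino on an aromatic carbon. Within the data shown here, no measured pair isolates this exact change. The closest guidance comes from compound 1, which carries the same 3-hydroxyphenyl group but a different sulfonyl partner and gives 1690 nM, a number well below that of compound 3. Together with the step from compound 2 to compound 3, this suggests the anilino aryl is the dominant variable among these compounds, and that the hydroxy group is associated with lower numbers than the amino group.

Compound 4 is therefore expected to give 2000 nM in this assay, within a range of 700 nM to 6000 nM, which means an estimated step of a 4.5-fold lower number from compound 3 to compound 4 (0.65 log units; beyond the scatter).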

Compound 4, half-maximal inhibitory concentration: 1700 nM
Estimate against measurement, compound 4: 1.2-fold (0.07 log units) above, and the stated range covers the measured number.
By their numbers in this assay, from the lowest: compounds 2, 1 and 4 (each within the scatter of the next); then compound 3.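

In this assay, the pair of compound 3 and compound 4 isolates the exchange of amino for hydroxy on an aromatic carbon meta to a large group, and a 5.3-fold lower number from compound 3 to compound 4 (0.72 log units; beyond the scatter) shows, with the rest of the molecule held constant, that this single change lies beyond the scatter. The step of a 1.0-fold higher number from compound 1 to compound 4 (0.00 log units; within the scatter) adds that, with the 3-hydroxyphenyl group in place, bromo in place of methyl on the other aromatic ring stays within the scatter, so the read-out does not distinguish these two substituents here. The step of a 1.5-fold higher number from compound 2 to compound 4 (0.19 log units; within the scatter) also lies within the scatter, so 3-hydroxyphenyl and 4-methoxyphenyl cannot be told apart on the nitrogen, and among the one-place comparisons only compound 3, with its 3-aminophenyl group, stands apart.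

No evidence accompanying these numbers bears on why amino and hydroxy differ at this position. The compounds shown leave open whether a methoxy group or a carboxylic acid on this same carbon would read like hydroxy or like amino, and whether the amino-to-hydroxy step would persist with methyl in place of bromo.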